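From Phenyl to 3,5-Dimethoxyphenyl on a Carbonyl Carbon

The source may report more compounds than this note shows. Statements on the series, on what has been measured and on what is new or still open speak of the compounds shown alone.

Within the data shown here, in a functional assay on SK-N-AS cells (Homo sapiens) for antiproliferative activity, with a stated time of 72 h (on this read-out higher numbers stand for weaker inhibition and lower numbers for stronger inhibition), compound 1 (`Cc1cc(C)cc(C(=O)N(CCC(=O)NCc2ccccc2)Cc2ccc(C(=O)NO)cc2)c1`) gives 1860 nM, and compound 2 (`O=C(CCN(Cc1ccc(C(=O)NO)cc1)C(=O)c1ccccc1)NCc1ccccc1`) gives 3310 nM, so compound 2 stands within the scatter of its only measured neighbour. Compound 3 (`COc1cc(OC)cc(C(=O)N(CCC(=O)NCc2ccccc2)Cc2ccc(C(=O)NO)cc2)c1`) carries 3,5-dimethoxyphenyl in place of phenyl on a carbonyl carbon. Among the measured compounds shown here, the one measured step at this place, a 1.8-fold higher number from compound 1 to compound 2 (0.25 log units; within the scatter), exchanges 3,5-dimethylphenyl for phenyl and stays small, so no change beyond the scatter is expected in this assay, though this single step is thin evidence. The expected step is a 1.4-fold lower number from compound 2 to compound 3 (0.16 log units; within the scatter). The estimate for compound 3 is 2300 nM, within an expected range of 900 nM to 5500 nM.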

Compound 3, half-maximal inhibitory concentration: 9470 nM
The estimate for compound 3 lay 4.1-fold (0.61 log units) below the measured number; the measured number lies above the stated range.
By their numbers in this assay, from the lowest: compounds 1 and 2 (each within the scatter of the next); then compound 3.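

The group on this carbonyl carbon can matter: in this assay 3,5-dimethoxyphenyl in place of phenyl gives a 2.9-fold higher number from compound 2 to compound 3 (0.46 log units; beyond the scatter) and the earlier step at this place stayed within the scatter. The two groups carrying a pair of substituents also differ, with a 5.1-fold higher number from compound 1 to compound 3 (0.71 log units; beyond the scatter) on going from 3,5-dimethylphenyl to 3,5-dimethoxyphenyl, so the identity of those substituents counts here. Nothing available explains why the number rises. From the compounds shown here alone, it remains open how a single methoxy group would behave at this place. A phenyl ring bearing an amine or a carboxylic acid also remains an open case.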